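Swapping the outer aryl amide cap on compound 1

A few compounds are considered here, and "the series" means these few. Any claim that something is new, unique, unknown or untested is made for them only; others in the source may bear on it.

Measured compounds:
compound 1 `COc1ccc(NC(=O)C2(C(=O)Nc3ccc(Nc4ncc5cc(C(=O)N(C)C)n(C6CCCC6)c5n4)cc3)CC2)cc1`: 74.4%
compound 2 `Nc1ccc(NC(=O)C2(C(=O)Nc3ccc(F)cc3)CC2)cc1F`: 16.3%

In a functional assay on A549 cells (Homo sapiens) for inhibition, read by CCK-8 assay, with a stated time of 72 h, tested at 1 uM (a lower number here means less inhibition of growth, a higher number more inhibition of growth at the concentration tested), compound 1 gives 74.4%, the higher of the two numbers shown, while compound 2 gives 16.3%, a gap beyond the scatter. Compound 2 lacks the core of compound 1, so its value offers little guidance for the step to compound 3 `COC(=O)c1cccc(NC(=O)C2(C(=O)Nc3ccc(Nc4ncc5cc(C(=O)N(C)C)n(C6CCCC6)c5n4)cc3)CC2)c1`. Compound 3 differs from compound 1 only at the outer amide cap: 3-(methoxycarbonyl)phenyl in place of 4-methoxyphenyl on an amide-type nitrogen. Going by the values given here, no measured pair shows this change, so only a modest shift is expected, slightly downward or none beyond the scatter, given as a number 8.4 percentage points lower from compound 1 to compound 3 (within the scatter). Compound 3 is therefore estimated at 66%, within 45% to 85%.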

Compound 3, percent growth inhibition at one concentration: 10.5%
Compound 3: the middle estimate sits 55.5 percentage points above what was measured, and the stated range ends above it.
By their numbers in this assay, from the lowest: compounds 3 and 2 (each within the scatter of the next); then compound 1.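

In this assay, the outer amide cap proves decisive: with the core of compound 1 unchanged, putting 3-(methoxycarbonyl)phenyl in place of 4-methoxyphenyl gives a number 63.9 percentage points lower from compound 1 to compound 3 (beyond the scatter). The growth inhibition seen with compound 1 therefore depends on this cap and not on the core alone. No measurement available here explains this loss.

Going by these compounds, whether the loss follows from the methoxycarbonyl group itself or from its place on the ring stays open, as the two caps differ in both. On these data alone, how a carboxylic acid or an amine on that ring would behave also remains open.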